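From ethyl to propyl on compound 2

The source may report more compounds than this note shows. Statements on the series, on what has been measured and on what is new or still open speak of the compounds shown alone.

In a functional assay on the whole organism for inhibition, with Rattus norvegicus as the target (a higher number here means that more compound is needed for the effect, a lower number that less compound is needed), compound 1 `CCCc1nc(CO)c(C(=O)OCC)n1Cc1ccc(-c2ccccc2C(=O)O)cc1` gives 1.5 mg/kg. Compound 2 `CCc1nc(CO)c(C(=O)O)n1Cc1ccc(-c2ccccc2C(=O)O)cc1` gives 0.27 mg/kg, the lower of the two numbers, and the gap between them lies beyond the scatter. Compound 3 `CCCc1nc(CO)c(C(=O)O)n1Cc1ccc(-c2ccccc2C(=O)O)cc1` is not yet measured. It carries methyl in place of hydrogen on a saturated chain carbon, two bonds along the chain from an aromatic carbon, methyl in place of hydrogen on a saturated chain carbon, two bonds along the chain from an aromatic carbon. Among the compounds with values here, no measured pair isolates this change. In this assay the estimated change is a 1.4-fold lower number from compound 2 to compound 3 (0.13 log units; within the scatter), expected to stay within the scatter. The expected value for compound 3 is 0.2 mg/kg, with an estimated range of 0.07 mg/kg to 0.6 mg/kg.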

Compound 3, dose for 50% inhibition: 0.069 mg/kg
Compound 3: middle estimate off by 2.9-fold (0.46 log units), on the high side; the measured number lies below the stated range.
By their numbers in this assay, from the lowest: compound 3; then compound 2; then compound 1.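

In this assay, within the data shown here, ethyl to propyl on the saturated chain carbon gives a 3.9-fold lower number from compound 2 to compound 3 (0.59 log units; beyond the scatter) as the first reading of this change on its own, so this position responds to a single added methyl. Hydrogen in place of ethyl on the oxygen next to a carbonyl group gives a 22-fold lower number from compound 1 to compound 3 (1.34 log units; beyond the scatter) and marks this as a large step on the same core. Nothing measured here accounts for either step.

As far as these compounds go, whether a longer chain such as butyl, or a branched chain such as isopropyl, lowers the number further remains open. So does the effect of an amide in place of the carboxylic acid at the site of the ester change.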